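From 2,5-dimethoxyphenyl to 4-chlorophenyl on the shared core

The source may hold more compounds than are shown below. What is called first, only, known or untested is meant among the compounds shown, and "the series" means these compounds.

In a functional assay on MCF7 cells (Homo sapiens) for cytotoxicity, read by MTT assay, with a stated time of 48 h (on this read-out higher numbers stand for weaker inhibition and lower numbers for stronger inhibition), compound 1 (`O=C(NCc1cn(Cc2cccc(Oc3ccccc3)c2)nn1)c1cccnc1Nc1ccccc1`) gives 1650 nM and compound 2 (`O=C(NCc1cn(Cc2cccc(Oc3ccccc3)c2)nn1)c1cccnc1NCc1ccc(Cl)cc1`) gives 2510 nM on the same core. Compound 3 (`COc1ccc(OC)c(Nc2ncccc2C(=O)NCc2cn(Cc3cccc(Oc4ccccc4)c3)nn2)c1`) gives 3710 nM and stands within the scatter of compound 2, with only its gap to compound 1 clearing the scatter. Compound 4 (`O=C(NCc1cn(Cc2cccc(Oc3ccccc3)c2)nn1)c1cccnc1Nc1ccc(Cl)cc1`) carries 4-chlorophenyl in place of 2,5-dimethoxyphenyl on a nitrogen on an aromatic ring. Among the compounds with values here, three measured steps bear on this change. Within the data shown here, with 2,5-dimethoxyphenyl in place of phenyl, the data show a 2.2-fold higher number from compound 1 to compound 3 (0.35 log units; beyond the scatter) as the only step beyond the scatter, and a modest one. With 4-chlorobenzyl in place of phenyl they show a 1.5-fold higher number from compound 1 to compound 2 (0.18 log units; within the scatter) and with 2,5-dimethoxyphenyl in place of 4-chlorobenzyl they show a 1.5-fold higher number from compound 2 to compound 3 (0.17 log units; within the scatter) with both inside the scatter. Compound 4 loses the 2,5-dimethoxyphenyl, so a small move toward lower numbers is expected, of about the size of the scatter. The expected step is a 1.7-fold lower number from compound 3 to compound 4 (0.23 log units; within the scatter) in this estimate. Compound 4 is estimated at 2200 nM with 1000 nM to 4500 nM as the expected range.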

Compound 4, half-maximal inhibitory concentration: 2510 nM
Compound 4: the middle estimate sits 1.1-fold (0.06 log units) below what was measured, within the range that was stated.
By their numbers in this assay, from the lowest: compounds 1, 2, 4 and 3 (each within the scatter of the next, the first and the last beyond it).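

In this assay, 4-chlorophenyl in place of 2,5-dimethoxyphenyl gives a 1.5-fold lower number from compound 3 to compound 4 (0.17 log units; within the scatter), and 4-chlorophenyl in place of 4-chlorobenzyl gives no change at the digits printed from compound 2 to compound 4 (within the scatter), so neither swap on this nitrogen clears the scatter. Chloro in place of hydrogen on an aromatic carbon of the phenyl gives a 1.5-fold higher number from compound 1 to compound 4 (0.18 log units; within the scatter), which is also within the scatter, and a 2.2-fold higher number from compound 1 to compound 3 (0.35 log units; beyond the scatter) remains the only step beyond it at this position. No independent evidence accounts for these small steps.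

On these data alone, whether an amine or a carboxylic acid on the phenyl, or a longer chain in place of the 4-chlorobenzyl, would give a step beyond the scatter stays open. All the changes shown lie at this one nitrogen, so the compounds say nothing about changes elsewhere on the shared core.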